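This account rests on a few compounds, and the source may have more. Where it says the series, first, only, none or still open, it means among the compounds named here.

Compound 1 `COc1ccc(C(c2ccccc2O)c2cccc3ccccc23)c(OC)c1OC` gives 17700 nM in a functional assay on MDA-MB-231 cells (Homo sapiens) for inhibition, read by sulforhodamine B assay, with a stated time of 48 h; on this read-out lower numbers stand for stronger inhibition and higher numbers for weaker inhibition.
Compound 2 `COc1cc(COC(c2ccc(OC)c(OC)c2OC)c2cccc3ccccc23)cc(OC)c1` gives > 20000 nM in this assay.
Compound 3 `COc1ccc(C(O)(C/C=C\c2ccccc2)c2cccc3ccccc23)c(OC)c1OC` gives 12800 nM in this assay.

All three measured compounds share a core and are weak in this assay. On these data alone, compound 2 stands apart in that no number is known for it: its result is only a limit, (the limit of > 20000 nM in this assay, at which 1 of the 3 values shown sits), so it is no more active than that boundary and how much weaker is unknown.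

Compound 4 `COc1ccc(C(OCc2ccccc2)c2cccc3ccccc23)c(OC)c1OC` is the unmeasured partner of compound 2. The change is small: phenyl in place of 3,5-dimethoxyphenyl on a saturated chain carbon bound to an oxygen on a saturated carbon. The 3,5-dimethoxybenzyl group becomes a plain benzyl group, and nothing else in the molecule moves.

For the measured compounds named here, no measured pair shows what this change does here. Since the whole set stays weak, and the closest analogues compound 1 and compound 3 sit within reach of the limit of compound 2, the expected step from compound 2 to compound 4 is an at least 1.1-fold lower number from compound 2 to compound 4 (0.04 log units; that floor lies within the scatter), that is, no movement beyond the scatter in either direction. Compound 4 is therefore estimated at 18000 nM in this assay, with a likely range from 8000 nM to 40000 nM, and a fair chance that only a limit is reported again.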

Compound 4, half-maximal inhibitory concentration: > 20000 nM
Compound 4 ended at the assay's limit (the forecaster's own chance of this, stated with the estimate: 45%); at least 1.1-fold (0.04 log units) between middle value and limit.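

Compound 4 also ends at a limit in this assay, so neither the plain benzyl group nor the 3,5-dimethoxybenzyl group gives a readable number here: the limit of > 20000 nM in this assay, at which 2 of the 4 values shown sit.

On these data alone, the step between these two limits cannot be read, so the size of any effect of this change remains unknown. Benzyloxy in place of 2-hydroxyphenyl on a saturated chain carbon bound to two aromatic carbons gives an at least 1.1-fold higher number from compound 1 to compound 4 (0.05 log units; that floor lies within the scatter), so this comparison alone does not establish a difference beyond the scatter.

The compounds shown leave open whether any group at this position can give a clearly stronger result on the shared core. A benzyl group carrying an amine or a carboxylic acid, or a longer chain in place of the benzyl group, could show whether a measurable number can be reached here.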